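The compounds below may be only part of what the source reports. "The series", "measured", "known", "first", "only" and "open" are said of these compounds alone.

In a functional assay on COLO 205 cells (Homo sapiens) for antiproliferative activity, read by luminescence, with a stated time of 72 h (on this read-out lower numbers stand for stronger inhibition and higher numbers for weaker inhibition), compound 1 `C[C@@H](CO)Nc1ncc(Cl)c(-c2cc3n(c2)C(=O)N([C@H](CO)c2cccc(Cl)c2)C3)n1` gives 81 nM and compound 2 `O=C1N([C@H](CO)c2cccc(Cl)c2)Cc2cc(-c3nc(NC4CCOCC4)ncc3Cl)cn21` gives 104 nM, two numbers that lie within the usual scatter of each other. Compound 3 `CC(C)Nc1cc(-c2cc3n(c2)C(=O)N([C@H](CO)c2cccc(Cl)c2)C3)c(Cl)cn1` is reported as "not active" (no number reported), so it adds no number to the comparison. Compound 2 therefore stands level with compound 1 among the numbers available.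

Compound 4 `C[C@H](CO)Nc1ncc(Cl)c(-c2cc3n(c2)C(=O)N([C@H](CO)c2cccc(Cl)c2)C3)n1` has yet to be measured in this assay. Its difference from compound 2 is 1-(hydroxymethyl)ethyl in place of oxan-4-yl on a nitrogen on an aromatic ring. In words, 1-(hydroxymethyl)ethyl stands in place of oxan-4-yl on a nitrogen on an aromatic ring.

Going by the values given here, only one measured step bears on this exchange: a 1.3-fold higher number from compound 1 to compound 2 (0.11 log units; within the scatter). That step involves the same two groups, runs in the opposite direction and stays within the scatter. Among the compounds with values here, it is a single observation, however, and nothing measured so far tests the defined stereocentre of the entering group, so the expectation needs a wide margin.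

On this evidence, no change beyond the scatter is expected, and the expected step is a 1.0-fold lower number from compound 2 to compound 4 (0.02 log units; within the scatter). For compound 4 the estimated value is 100 nM, with an expected range of 40 nM to 300 nM.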

Compound 4, half-maximal inhibitory concentration: "not active" (no number reported)
The entry for compound 4 holds no number; there is nothing to compare the estimate with.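

Compound 4 is reported as "not active" without a number in this assay, so no new step can be read from compound 2 to compound 4. The compounds shown leave open how far the configuration of the 1-(hydroxymethyl)ethyl group alone separates the numbered compound 1 from compound 4, and the one relevant point is this: the fact that compounds 1 and 4 differ only in the configuration as drawn.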